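Compound 4: aryl replacement on the ethenyl chain

A few compounds are considered here, and "the series" means these few. Any claim that something is new, unique, unknown or untested is made for them only; others in the source may bear on it.

Series notes. Compound 1 `COc1ccc(OC)c(/C=C/C(=O)Nc2cc3c(Nc4ccc(F)c(Cl)c4)ncnc3cc2O[C@H]2CCOC2)c1` is one of three members measured in a functional assay on HeLa cells (Homo sapiens) for cytotoxicity, read by MTT assay, with a stated time of 72 h (a higher number here means a weaker inhibitor, a lower number a stronger inhibitor), where compound 1 gives 26800 nM. Compound 2 `O=C(/C=C/c1cccc(Cl)c1Cl)Nc1cc2c(Nc3ccc(F)c(Cl)c3)ncnc2cc1O[C@H]1CCOC1` gives 30500 nM in this assay, and compound 3 `COc1ccc(/C=C/C(=O)Nc2cc3c(Nc4ccc(F)c(Cl)c4)ncnc3cc2O[C@H]2CCOC2)c(OC)c1` gives 26500 nM. Compound 1 stands second highest of the three numbers, nearest to compound 3 and furthest from compound 2, yet every step among them lies within the scatter: a 1.1-fold higher number from compound 1 to compound 2 (0.06 log units; within the scatter), a 1.0-fold lower number from compound 1 to compound 3 (0.00 log units; within the scatter) and a 1.2-fold lower number from compound 2 to compound 3 (0.06 log units; within the scatter). No order among the three can be read from these numbers.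

Compound 4 `O=C(/C=C/c1ccc(F)cc1Cl)Nc1cc2c(Nc3ccc(F)c(Cl)c3)ncnc2cc1O[C@H]1CCOC1` is not yet measured. It differs from compound 1 as follows: 2-chloro-4-fluorophenyl in place of 2,5-dimethoxyphenyl on a double-bonded chain carbon bound to a double-bonded chain carbon. Within the data shown here, the closest precedent is the step from compound 1 to compound 2, which also exchanges the 2,5-dimethoxyphenyl for a 2,3-dichlorophenyl at the same place and came out within the scatter. The exchange of 2,5-dimethoxyphenyl for 2,4-dimethoxyphenyl, from compound 1 to compound 3, likewise changed nothing beyond the scatter. Among the measured compounds shown here, nothing among the measured compounds points to a shift in this assay for compound 4 beyond the scatter in either direction. Compound 4 is accordingly expected to give about 28000 nM in this assay, within a range of 14000 nM to 56000 nM. The expected step is a 1.0-fold higher number from compound 1 to compound 4 (0.02 log units; within the scatter).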

Compound 4, half-maximal inhibitory concentration: 37500 nM
Beside the measured number, compound 4's estimate is 1.3-fold (0.13 log units) below it; measured number inside the range.
By their numbers in this assay, from the lowest: compounds 3, 1, 2 and 4 (each within the scatter of the next).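

In this assay, among these compounds, the 2-chloro-4-fluorophenyl group at this place on the ethenyl chain gives no step that stands out from the scatter: a 1.4-fold higher number from compound 1 to compound 4 (0.15 log units; within the scatter) and a 1.4-fold higher number from compound 3 to compound 4 (0.15 log units; within the scatter) and also a 1.2-fold higher number from compound 2 to compound 4 (0.09 log units; within the scatter) all stay inside it. Among the compounds shown here, a ring bearing both fluorine and chlorine therefore joins the 2,3-dichlorophenyl of compound 2 as a second halogen-bearing aryl group, and the four numbers show no separation between this halogen pair and the dimethoxyphenyl pair of compound 1 and compound 3, with no compound among the four going against that reading. No measurement bears on why the numbers stay together across these aryl exchanges.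

Still open, as far as these compounds go, is whether a ring carrying an amine or a carboxylic acid, or a longer saturated chain in place of the aryl ring at this place, would move the number beyond the scatter in this assay at all. Also open, from the compounds shown here alone, is whether the aryl group has any influence on these numbers or whether they are set by the shared core, which stays the same in all four compounds.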